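A few compounds are considered here, and "the series" means these few. Any claim that something is new, unique, unknown or untested is made for them only; others in the source may bear on it.

Compound 1, with the structure `COc1ccc(C(=O)NCCC2CCN(S(=O)(=O)NC(=O)NC[C@@H]3C[C@@H]4C=C[C@@H]3C4)CC2)cn1`, was tested in a functional assay on the whole organism (blood) with Rattus norvegicus as the target, with stated times of 24 h and 1 h, at a dose of 5 mg/kg by the intraperitoneal route; a lower number here means a weaker effect, a higher number a stronger effect of the compound at the dose given. In this assay compound 1 gives 11%. Within the data shown here, the only other compound measured here is compound 2, with the structure `O=C(NC1CCCCC1)NS(=O)(=O)N1CCC(CCNC(=O)c2ccnc3ccccc23)CC1`; in this assay compound 2 gives 16%. These two numbers lie within the usual scatter of each other, so neither compound can be set apart from the other, and both readings are small.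

Compound 3, with the structure `O=C(NC[C@@H]1C[C@@H]2C=C[C@@H]1C2)NS(=O)(=O)N1CCC(CCNC(=O)c2cc(Cl)cc3cccnc23)CC1`, has not yet been measured. It differs from compound 1 in one place: 6-chloroquinolin-8-yl in place of 6-methoxypyridin-3-yl on a carbonyl carbon. Among the measured compounds shown here, no pair of measured compounds differs in just one place, so there is no measured step to lean on, and the two compounds that have been measured both show only a weak effect at this dose. On that footing the step from compound 1 to compound 3 is expected to be small, a number 6 percentage points higher from compound 1 to compound 3 (within the scatter), and may not exceed the scatter. For compound 3 the expected reading in this assay is 17%, with a range from 4% to 34%.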

Compound 3, a percentage reported as activity, at one dose (the size of the read-out at that dose, not a potency): 35%
Estimate against measurement, compound 3: 18 percentage points below; the whole stated range lies below it.
By their numbers in this assay, from the lowest: compounds 1 and 2 (each within the scatter of the next); then compound 3.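

In this assay, among these compounds, putting 6-chloroquinolin-8-yl in place of 6-methoxypyridin-3-yl on a carbonyl carbon gives a number 24 percentage points higher from compound 1 to compound 3 (beyond the scatter), the first single change in this set whose size can be read. It shows that the reading at this dose is not fixed by the rest of the molecule: with everything else held constant, the group on this carbonyl carbon is enough to move it beyond the usual scatter. Nothing measured here accounts for why this exchange raises the reading, so the step stands as an observation without an explanation.

The exchange alters several things at once, as the entering group adds an aromatic ring of carbon only and a chlorine, while the leaving group takes its oxygen with it, so one step cannot show which of these differences matters. As far as these compounds go, an unsubstituted quinolin-8-yl would separate the second ring from the chlorine and a plain phenyl would test a simpler ring at this place, while the effect at other doses stays open, as a reading at one dose is not a potency.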